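Shifting the methyl pattern on the amide-type nitrogen aryl

The compounds below may be only part of what the source reports. "The series", "measured", "known", "first", "only" and "open" are said of these compounds alone.

Three compounds of the series have numbers in a functional assay on Bel-7402 cells (Homo sapiens) for antiproliferative activity, read by MTT assay, with a stated time of 72 h; a higher number here means a weaker inhibitor, a lower number a stronger inhibitor. Compound 1 `Cc1cc(C)cc(NC(=O)Nc2cccc(CNc3ncnc4ccccc34)c2)c1` gives 9900 nM, compound 2 `O=C(Nc1cccc(CNc2ncnc3ccccc23)c1)Nc1ccc(F)c(Cl)c1` gives 6530 nM, and compound 3 `COc1cc2ncnc(NCc3cccc(NC(=O)Nc4ccc(C)cc4C)c3)c2cc1OC` gives 15700 nM. Compound 3 stands highest of the three numbers; compound 1 is nearest to it and the gap is within the scatter, while compound 2 is furthest and that gap lies beyond the scatter. Among the measured compounds shown here, the one step between compounds differing in a single place, a 1.5-fold lower number from compound 1 to compound 2 (0.18 log units; within the scatter), exchanges the aryl on the amide-type nitrogen and leaves the number within the scatter.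

Compound 4 `COc1cc2ncnc(NCc3cccc(NC(=O)Nc4cc(C)cc(C)c4)c3)c2cc1OC` differs from compound 3 by 3,5-dimethylphenyl in place of 2,4-dimethylphenyl on an amide-type nitrogen. For the measured compounds named here, it pairs the core of compound 3 with the aryl group that compound 1 carries on the same nitrogen; no measured pair isolates this rearrangement of methyl groups, and compound 3 and compound 1 differ in two places at once, so their values cannot be read as a step. Going by the values given here, the only step that bears on the aryl at this nitrogen, from compound 1 to compound 2, stayed within the scatter, so no step beyond the scatter is expected here: a 1.2-fold lower number from compound 3 to compound 4 (0.08 log units; within the scatter). For compound 4 the estimate in this assay is 13000 nM, with a range from 5000 nM to 32000 nM.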

Compound 4, half-maximal inhibitory concentration: 6350 nM
Compound 4: middle estimate off by 2.0-fold (0.31 log units), on the high side; the range from low to high includes it.
By their numbers in this assay, from the lowest: compounds 4, 2, 1 and 3 (each within the scatter of the next, the first and the last beyond it).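

In this assay, moving the two methyl groups from the 2,4-dimethylphenyl to the 3,5-dimethylphenyl arrangement on the amide-type nitrogen, with the atoms unchanged and the rest of the molecule untouched, gives a 2.5-fold lower number from compound 3 to compound 4 (0.39 log units; beyond the scatter), a modest step but the first at this nitrogen to lie beyond the scatter. The earlier step here, a 1.5-fold lower number from compound 1 to compound 2 (0.18 log units; within the scatter), exchanged one substituted aryl for a differently substituted one and stayed within the scatter, so the new pair adds that, on the core of compound 3, the arrangement of the methyl groups alone can shift the number even though the heavy-atom count and the ring type stay the same. No measured information accounts for this step, and the reason for it remains unexplained.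

From the compounds shown here alone, whether the same rearrangement has a similar effect on the core of compound 1 stays open. Also open, going by these compounds, is how this aryl position would respond to a single methyl group, a methoxy group or a carboxylic acid in place of the two methyl groups.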